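The source may report more compounds than this note shows. Statements on the series, on what has been measured and on what is new or still open speak of the compounds shown alone.

Measured so far:
compound 1 `COc1ccc(N2CCN(C(=S)SCc3ccc(C(=O)Nc4ccccc4N)cc3)CC2)cc1` — 25.3%
compound 2 `COC(=O)c1ccc2c(c1)CCN2C(=S)SCc1ccc(C(=O)Nc2ccccc2N)cc1` — 37.8%

Among the measured compounds shown here, in a functional assay on MGC-803 cells (Homo sapiens) for antiproliferative activity, read by CCK-8 assay, with a stated time of 72 h, tested at 2 uM (a lower number here means a weaker effect, a higher number a stronger effect of the compound at the concentration tested), compound 1 gives 25.3%, the lower of the two numbers available so far. Compound 2 gives 37.8% in this assay, a number higher by an amount beyond the usual scatter. The two measured compounds differ from each other in more than one place, so nothing further is read from that pair than what the two values show.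

Compound 3 `Nc1ccccc1NC(=O)c1ccc(CSC(=S)N2CCN(c3ccccc3)CC2)cc1` is not yet measured. Set against compound 1, the change is hydrogen in place of methoxy on an aromatic carbon, cut one bond further out, 4-methoxyphenyl to phenyl. For the measured compounds named here, no pair of measured compounds isolates this change, so its size rests on the structural change alone. A small step is expected in this assay, in no set direction, not beyond the scatter; the step of a number 1.3 percentage points lower from compound 1 to compound 3 (within the scatter) is therefore expected to stay within that scatter. For compound 3 the estimate in this assay is 24%, with a range of 8% to 40%.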

Compound 3, a percentage reported as inhibition, at one concentration (the size of the read-out at that concentration, not a potency): 42.3%
The estimate for compound 3 lay 18.3 percentage points below the measured number; measured number above the stated range.
By their numbers in this assay, from the lowest: compound 1; then compounds 2 and 3 (each within the scatter of the next).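

In this assay, hydrogen in place of methoxy on an aromatic carbon, para to a large group, is a measurable change: the step reads a number 17 percentage points higher from compound 1 to compound 3 (beyond the scatter), and it is modest in size. Among the compounds shown here, this is the first pair that differs in one place, and it shows that the substituent at this position of the six-membered aromatic ring of carbon only affects the read-out at the concentration tested, with phenyl giving the higher number of the two and 4-methoxyphenyl the lower. No measurement available here accounts for this step, and its cause stays unassigned.

Only methoxy and hydrogen appear at this position in the compounds shown, so a single pair gives the direction of one change and does not show whether the step is particular to methoxy or would follow any group placed there. As far as these compounds go, whether an ethoxy group, a chlorine atom, an amine or a carboxylic acid at the same carbon would stay close to compound 1 or to compound 3 remains open, as does the same change on a different core.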